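Removing the diphosphate from a triphosphate nucleotide

A few compounds are considered here, and "the series" means these few. Any claim that something is new, unique, unknown or untested is made for them only; others in the source may bear on it.

Measured compounds:
- compound 1, `O=c1ccn([C@@H]2O[C@H](COP(=O)(O)OP(=O)(O)OP(=O)(O)O)[C@@H](O)[C@H]2O)c(=S)[nH]1`: 50 nM
- compound 2, `Cc1cc(=O)n([C@@H]2O[C@H](COP(=O)(O)OP(=O)(O)OP(=O)(O)O)[C@@H](O)[C@H]2O)c(=O)[nH]1`: > 1000 nM

Of the compounds shown here, two have been measured in an in vitro functional assay on 1321-N1 cells for agonist activity at P2Y purinoceptor 2 (Homo sapiens); on this read-out higher numbers stand for an effect only at larger amounts of compound and lower numbers for an effect already at smaller amounts. Compound 1 gives 50 nM in this assay. For compound 2 the value is only a limit of this assay, > 1000 nM, so no number is known for it; one of the two measured values sits at this limit (the limit of > 1000 nM in this assay, at which 1 of the 2 values shown sits). Going by the values given here, the one measured step, an at least 20-fold higher number from compound 1 to compound 2 (1.30 log units; beyond the scatter), exchanges the heterocycle on the saturated ring carbon of the shared core.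

Compound 3, `Cc1cc(=O)n([C@@H]2O[C@H](COP(=O)(O)O)[C@@H](O)[C@H]2O)c(=O)[nH]1`, has not yet been measured in this assay. It differs from compound 2 by a hydrogen atom in place of a group of 8 heavy atoms (6 oxygen, 2 phosphorus; no ring), on an oxygen. Among the compounds with values here, none of the measured steps touches the phosphate chain, so the size of this change cannot be read from them; the only guide is that compound 2 itself already stands at the limit. Compound 3 is therefore expected to remain at or beyond that limit as well, with an estimated step that the limit leaves unreadable from compound 2 to compound 3 from compound 2 to compound 3. For compound 3 the estimate in this assay is 5000 nM, between 1000 nM and 30000 nM.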

Compound 3, half-maximal effective concentration: > 100000 nM
Compound 3 ended at the assay's limit (the forecaster's own chance of this, stated with the estimate: 85%); middle value at least 20-fold (1.30 log units) from the limit.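

For compound 2 the value > 1000 nM is a limit and not a number. For compound 3 the value > 100000 nM is also a limit and not a number, so no step can be read between compound 2 and compound 3. The compounds shown leave open what a hydrogen atom in place of this group of 8 heavy atoms does where a real number is available, as in compound 1.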